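A Ring Nitrogen Substituent Change Tested Twice

The source may hold more compounds than are shown below. What is called first, only, known or untested is meant among the compounds shown, and "the series" means these compounds.

Compound 1 `COc1ncc(-c2ccc3c(c2)N(C2CC2)C(=O)CO3)cc1NS(=O)(=O)c1ccc(F)cc1` and compound 3 `COc1ccc(N2C(=O)COc3ccc(-c4cnc(OC)c(NS(=O)(=O)c5ccc(F)cc5)c4)cc32)cc1` share one core, while compound 2 `O=C1COc2ccc(-c3cccc(NS(=O)(=O)c4ccc(F)cc4)c3)cc2N1C1CC1` and compound 4 `COc1ccc(N2C(=O)COc3ccc(-c4cccc(NS(=O)(=O)c5ccc(F)cc5)c4)cc32)cc1` share another; the difference between the two cores is not broken down here. In a functional assay on MCF7 cells (Homo sapiens) for antiproliferative activity, read by MTT assay, with a stated time of 72 h (a lower number here means a stronger inhibitor, a higher number a weaker inhibitor), compound 1 gives 35200 nM, and compound 3 gives 8260 nM. The two differ by a single change, (4-methoxyphenyl in place of cyclopropyl on an amide-type nitrogen in a ring), which produced the step of a 4.3-fold lower number from compound 1 to compound 3 (0.63 log units; beyond the scatter). Compound 2 gives only a limit in this assay, > 40000 nM, one of the values sitting at the limit of > 40000 nM in this assay, at which 1 of the 3 values shown sits. Compound 4 carries the same change relative to compound 2, (4-methoxyphenyl in place of cyclopropyl on an amide-type nitrogen in a ring), at the same place on its core. Since compound 2 gives only a limit, the starting point for compound 4 is not pinned down. The expectation for compound 4 rests on the step of a 4.3-fold lower number from compound 1 to compound 3 (0.63 log units; beyond the scatter) made by the same change. In this assay compound 4 is therefore expected to give 15000 nM, with a likely range from 5000 nM to 40000 nM. That estimate corresponds to an expected step of an at least 2.6-fold lower number from compound 2 to compound 4 (0.42 log units; beyond the scatter).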

Compound 4, half-maximal inhibitory concentration: 32400 nM
The estimate for compound 4 lay 2.2-fold (0.33 log units) below the measured number; the measured number falls inside the stated range.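

In this assay, 4-methoxyphenyl in place of cyclopropyl on the amide-type nitrogen in a ring gives an at least 1.2-fold lower number from compound 2 to compound 4 (0.09 log units; that floor lies within the scatter) and so provides only a floor for the step on this second core. Compound 2 gives > 40000 nM, which is a limit and not a number. The result therefore does not show that the change carries over from one core to the other with the same size, nor does it show that the size differs, and the floor alone does not establish a real step on the second core: the same change on two cores in this assay, a 4.3-fold lower number (0.63 log units; beyond the scatter) from compound 1 to compound 3 and an at least 1.2-fold lower number (0.09 log units; that floor lies within the scatter) from compound 2 to compound 4; the limit leaves it open whether they differ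

The compounds shown leave open how the nitrogen substituent would read on either core with a group other than cyclopropyl or 4-methoxyphenyl, such as a longer carbon chain or an amine. For the compounds shown here, they also leave open how much the difference between the two cores contributes by itself, as the only pair that could speak to it includes the limit for compound 2.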